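The source may hold more compounds than are shown below. What is called first, only, known or untested is meant among the compounds shown, and "the series" means these compounds.

In a functional assay on DU-145 cells (Homo sapiens) for antiproliferative activity, read by MTT assay, with a stated time of 48 h (a higher number here means a weaker inhibitor, a lower number a stronger inhibitor), compound 1 (`C/C(=C\CC/C(C)=C/CC[C@@H]1[C@@]2(C)CCC(=O)C(C)(C)[C@H]2CC[C@@]1(C)O)CC/C=C(\C)C(=O)OCc1cn(-c2ccccc2C(F)(F)F)nn1`) gives > 150000 nM, a limit and not a number. Compound 2 (`C/C(=C\CC/C(C)=C/CC[C@@H]1[C@@]2(C)CCC(=O)C(C)(C)[C@H]2CC[C@@]1(C)O)CC/C=C(\C)C(=O)OCc1cn(-c2ccc(Br)cc2)nn1`) likewise gives only a limit, > 150000 nM. Compound 3 (`C/C(=C\CC/C(C)=C/CC[C@@H]1[C@@]2(C)CCC(=O)C(C)(C)[C@H]2CC[C@@]1(C)O)CC/C=C(\C)C(=O)OCc1cn(-c2cccc(C(F)(F)F)c2)nn1`) also gives only a limit, > 150000 nM. For the measured compounds named here, its place is therefore shared, and the series so far shows (the limit of > 150000 nM in this assay, at which 3 of the 3 values shown sit). Compound 4 (`C/C(=C\CC/C(C)=C/CC[C@@H]1[C@@]2(C)CCC(=O)C(C)(C)[C@H]2CC[C@@]1(C)O)CC/C=C(\C)C(=O)OCc1cn(-c2cccc(O)c2)nn1`) carries hydroxy in place of trifluoromethyl on an aromatic carbon of compound 3: hydroxy in place of trifluoromethyl on an aromatic carbon. Going by the values given here, three measured steps bear on this change, though they give no size to carry over: a step that the two limits leave unreadable from compound 1 to compound 2, a step that the two limits leave unreadable from compound 1 to compound 3 and a step that the two limits leave unreadable from compound 2 to compound 3. No step beyond the scatter is therefore expected in this assay, and no direction can be fixed, so the expected step is a number no higher from compound 3 to compound 4 (the limit leaves the size open). Compound 4 is expected near 150000 nM, with an estimated range of 50000 nM to 300000 nM.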

Compound 4, half-maximal inhibitory concentration: 28400 nM
The estimate for compound 4 lay 5.3-fold (0.72 log units) above the measured number, outside the stated range (below it).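

In this assay, for the compounds shown here, hydroxy on this aromatic carbon, meta to a large group, gives the only step from compound 3 that can be read, an at least 5.2-fold lower number from compound 3 to compound 4 (0.72 log units; beyond the scatter). The 3-hydroxyphenyl group also separates itself from the other two aryl groups on the aromatic nitrogen, with an at least 5.2-fold lower number from compound 2 to compound 4 (0.72 log units; beyond the scatter) and an at least 5.2-fold lower number from compound 1 to compound 4 (0.72 log units; beyond the scatter), whereas the steps among compound 1, compound 2 and compound 3 cannot be read. Only compound 4 gives a number rather than a limit: the limit of > 150000 nM in this assay, at which 3 of the 4 values shown sit.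

Going by these compounds, the true size of these steps stays open, since each starts from a limit. On these data alone, whether an amine or a methoxy group on this carbon would also give a number is equally open.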